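The source may report more compounds than this note shows. Statements on the series, on what has been measured and on what is new or still open speak of the compounds shown alone.

Compound 1 `COc1ccc(C(=O)NNc2c(Br)cccc2Br)cc1`: > 100000 nM
Compound 2 `CCOc1ccc(C(=O)NNc2c(Br)cccc2Br)cc1`: > 100000 nM
Compound 3 `CCCOc1ccc(C(=O)NNc2c(Br)cccc2Br)cc1`: > 100000 nM

All three results come from a toxicity assay on MDCK cells (Canis lupus familiaris) for cytotoxicity, read by CCK-8 assay, with a stated time of 48 h (on this read-out lower numbers stand for higher toxicity in this test and higher numbers for lower toxicity in this test), and each one is a limit of the assay, not a number. Compound 3 gives > 100000 nM, which is such a limit. Compound 4 `N#Cc1ccc(C(=O)NNc2c(Br)cccc2Br)cc1` differs from compound 3 by cyano in place of propoxy on an aromatic carbon, with cyano in place of propoxy on an aromatic carbon, para to a large group.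

Three measured steps change the saturated chain at this place: a step that the two limits leave unreadable from compound 1 to compound 2, a step that the two limits leave unreadable from compound 1 to compound 3 and a step that the two limits leave unreadable from compound 2 to compound 3. None has a readable size, and none replaces the chain with another kind of group, so they bear on the change only loosely. The series offers (the limit of > 100000 nM in this assay, at which 3 of the 3 values shown sit). On that basis, no step beyond the usual scatter is expected, and this assay may again report only a limit. The expected step is a number no higher from compound 3 to compound 4 (the limit leaves the size open). The estimate for compound 4 is 100000 nM, within an expected range of 40000 nM to 200000 nM.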

Compound 4, half-maximal cytotoxic concentration: > 100000 nM
Compound 4: only a limit was reported; the forecaster's own chance of this, stated with the estimate: 75%; the middle value lies on the limit itself.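

Compound 4 gives > 100000 nM in this assay, which is a limit and not a number. No step from compound 1, compound 2 or compound 3 to compound 4 can be read, because all four sit at a limit: the limit of > 100000 nM in this assay, at which 4 of the 4 values shown sit.

The compounds shown leave open how toxic each one is to these cells, and whether cyano differs from methoxy, ethoxy or propoxy in this test.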